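Hydroxyphenyl series: three measured, one awaiting measurement

The source may report more compounds than this note shows. Statements on the series, on what has been measured and on what is new or still open speak of the compounds shown alone.

compound 1 `Oc1ccc(-c2cc(-c3cccs3)cc(-c3cccc(O)c3)n2)cc1` gives 1.1% in an assay on isolated protein for inhibition of DNA topoisomerase 1 (Homo sapiens), with a stated time of 30 min, tested at 20 uM; a higher number here means a stronger effect of the compound at the concentration tested, a lower number a weaker effect
compound 2 `Oc1ccc(-c2cc(-c3cccs3)cc(-c3ccc(O)cc3)n2)cc1` gives 0.9% in this assay
compound 3 `Oc1cccc(-c2cc(-c3ccco3)cc(-c3ccccc3O)n2)c1` gives 0% in this assay

The change 4-hydroxyphenyl in place of 3-hydroxyphenyl on an aromatic carbon gives the step of a number 0.2 percentage points lower from compound 1 to compound 2 (within the scatter). The difference between the core of compound 1 and the core of compound 3 is not broken down here. Compound 4 `Oc1ccc(-c2cc(-c3ccco3)cc(-c3ccccc3O)n2)cc1` arises from compound 3 by 4-hydroxyphenyl in place of 3-hydroxyphenyl on an aromatic carbon, the same kind of change as from compound 1 to compound 2, though at a place that is meta to a 2-hydroxyphenyl group and meta to a furan-2-yl group rather than meta to a 4-hydroxyphenyl group and meta to a thiophen-2-yl group. A step of a number 0.5 percentage points higher from compound 3 to compound 4 (within the scatter) is expected, beside a number 0.2 percentage points lower from compound 1 to compound 2 (within the scatter), because compound 3 gives 0% and all three measured numbers lie within the scatter of one another. For compound 4 the expected value in this assay is 0.5%, estimated between 0% and 5%.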

Compound 4, a percentage reported as inhibition, at one concentration (the size of the read-out at that concentration, not a potency): 0%
Beside the measured number, compound 4's estimate is 0.5 percentage points above it; low and high end bracket the measured number.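

In this assay the change to 4-hydroxyphenyl in place of 3-hydroxyphenyl gives no change at the digits printed from compound 3 to compound 4 (within the scatter) and the step carries over with no difference to be read between the two cores: the same change on two cores in this assay, a number 0.2 percentage points lower (within the scatter) from compound 1 to compound 2 and no change at the digits printed (within the scatter) from compound 3 to compound 4, 0.2 percentage points apart, within the scatter of two such steps. Among these compounds, all the numbers sit near the bottom of the read-out, so this agreement shows only that the change leaves inhibition at that level on both cores. It does not show that the step would carry over to a core with sizeable inhibition.

Still open, from the compounds shown here alone, is whether thiophen-2-yl and furan-2-yl differ on an otherwise identical core. Also open, going by these compounds, is whether an amine or a carboxylic acid on the phenyl rings, in place of the hydroxyl, would lift the read-out at all.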